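Replacing 2-chlorophenyl with 4-ethoxyphenyl in a benzyl amine series

This account rests on a few compounds, and the source may have more. Where it says the series, first, only, none or still open, it means among the compounds named here.

Compound 1 `COc1cc(N)c(Cl)cc1NC(=O)C1CCN(Cc2ccccc2Cl)CC1`: > 4 mg/kg
Compound 2 `COc1cc(N)c(Cl)cc1NC(=O)C1CCN(Cc2ccc(F)cc2)CC1`: 0.6 mg/kg
Compound 3 `COc1cc(N)c(Cl)cc1NC(=O)C1CCN(Cc2cccc(C)c2)CC1`: 2.4 mg/kg

In a functional assay on the whole organism for antagonist activity, with Mus musculus as the target (on this read-out higher numbers stand for an effect only at larger amounts of compound and lower numbers for an effect already at smaller amounts), compound 1 gives only a limit of the assay, > 4 mg/kg. Compound 2 gives 0.6 mg/kg, and compound 3 gives 2.4 mg/kg. Compound 4 `CCOc1ccc(CN2CCC(C(=O)Nc3cc(Cl)c(N)cc3OC)CC2)cc1` is not yet measured; it differs from compound 1 by 4-ethoxyphenyl in place of 2-chlorophenyl on a saturated chain carbon bound to an amine nitrogen in a ring. Two measured steps also leave the 2-chlorophenyl group: an at least 6.6-fold lower number from compound 1 to compound 2 (0.82 log units; beyond the scatter), and an at least 1.6-fold lower number from compound 1 to compound 3 (0.22 log units; that floor lies within the scatter). Both point toward lower numbers, the larger one with the 4-fluorophenyl compound. On these data alone, since compound 1 sits at the limit (the limit of > 4 mg/kg in this assay, at which 1 of the 3 values shown sits), the true size of either step is unknown. For compound 4 a lower number than for compound 1 is expected, an at least 2.6-fold lower number from compound 1 to compound 4 (0.42 log units; beyond the scatter). The estimate for compound 4 is 1.5 mg/kg, from 0.4 mg/kg to 5 mg/kg.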

Compound 4, dose for half-maximal effect: 6.3 mg/kg
Estimate against measurement, compound 4: 4.2-fold (0.62 log units) below, outside the stated range (above it).
By their numbers in this assay, from the lowest: compound 2; then compound 3; then compound 4.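

The 4-ethoxyphenyl group does not carry on the gain seen with 4-fluorophenyl, as the measured steps run the other way: a 2.6-fold higher number from compound 3 to compound 4 (0.42 log units; beyond the scatter), and an 11-fold higher number from compound 2 to compound 4 (1.02 log units; beyond the scatter). The second step changes only ethoxy for fluoro on an aromatic carbon, so at this place the choice of that one group can move the number a long way. The step from the first compound of the series cannot be read, because compound 1 stands at a limit: the limit of > 4 mg/kg in this assay, at which 1 of the 4 values shown sits.

On these data alone, whether methoxy or hydroxy in place of ethoxy would bring the number back towards that of compound 2 stays open.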